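Second hydroxy on the pendant ring of compound 3

The source may hold more compounds than are shown below. What is called first, only, known or untested is meant among the compounds shown, and "the series" means these compounds.

compound 1 `COc1ccc(-c2cc3cccc(OC)c3oc2=O)cc1` in an assay on CHO cells for displacement of a labelled ligand from adenosine receptor A2b (Homo sapiens), read by radioligand binding; a lower number here means a stronger inhibitor, a higher number a weaker inhibitor: > 30000 nM
compound 2 `O=c1oc2c(O)c(O)ccc2cc1-c1ccccc1` in this assay : > 30000 nM
compound 3 `O=c1oc2c(O)c(O)ccc2cc1-c1ccc(O)cc1` in this assay : > 30000 nM

Each of these values is a limit of the assay, not a number; all three sit at the limit of > 30000 nM in this assay, at which 3 of the 3 values shown sit. Compound 3 therefore stands only as a limit, with nothing to set it apart from compound 1 or compound 2. Within the data shown here, the one measured step of the same kind, a step that the two limits leave unreadable from compound 2 to compound 3, is unreadable in size.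

Compound 4 `O=c1oc2c(O)c(O)ccc2cc1-c1ccc(O)c(O)c1` differs from compound 3 by hydroxy in place of hydrogen on an aromatic carbon. Among the measured compounds shown here, the only step bearing on this change is the unreadable one just named, so no shift beyond the scatter can be expected; the step that the limit leaves unreadable from compound 3 to compound 4 is estimated as essentially none. Compound 4 is expected most likely to be reported as a limit again, with an estimate of 40000 nM (range 10000 nM to 150000 nM).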

Compound 4, inhibition constant: > 30000 nM
Compound 4 ended at the assay's limit (the forecaster's own chance of this, stated with the estimate: 80%); the middle value lies beyond the limit too.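

Compound 3 and compound 4 both stand at a limit, not a number, so no step between them can be read: the limit of > 30000 nM in this assay, at which 4 of the 4 values shown sit.

The compounds shown leave open whether any substitution on the pendant ring gives a readable value in this assay.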